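The compounds below may be only part of what the source reports. "The series", "measured", "known", "first", "only" and "open" are said of these compounds alone.

Of the compounds shown here, three have been measured in an ADME assay on a cell-free system (plasma, Homo sapiens) for metabolic stability, read by LC-MS, with a stated time of 4 h, tested at 100 uM; a lower number here means that less of the compound is left, a higher number that more of the compound is left. Compound 1 `Cn1c(Sc2c(F)cc(C(=O)NO)cc2F)nnc1-c1cccnn1` gives 100%, compound 3 `O=C(NO)c1cc(F)c(Cc2nnc(-c3ccncc3)s2)c(F)c1` gives 93%, and compound 2 `Nc1ccc(-c2nnn(Cc3c(F)cc(C(=O)NO)cc3F)n2)cc1` gives 88%. Compound 1 and compound 3 lie within the scatter of each other, while compound 2 stands below compound 1 by more than the scatter. No two of these compounds differ in one place only, so the data offer no direct measure of a single structural change.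

Compound 4 `Cc1cc(-c2nnc(Sc3c(F)cc(C(=O)NO)cc3F)n2C)nn1C` has not yet been measured. It keeps the core of compound 1 and carries 1,5-dimethyl-1H-pyrazol-3-yl in place of pyridazin-3-yl on an aromatic carbon. Across the three different structures measured so far, most of the compound remains, and this holds for compound 2 at 88% too. A similar result is therefore expected after this change. In this assay, the estimated step, a number 5 percentage points lower from compound 1 to compound 4 (within the scatter), is small, downward and within the scatter. For compound 4 the estimated value is 95%, with an expected range from 85% to 100%.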

Compound 4, percent of the compound remaining: 92%
For compound 4 the middle estimate is 3 percentage points above the measured one; measured number inside the range.
By their numbers in this assay, from the lowest: compounds 2, 4, 3 and 1 (each within the scatter of the next, the first and the last beyond it).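

In this assay, going by these compounds alone, this position now has a direct measure of a single change, which the earlier compounds could not give: the step is a number 8 percentage points lower from compound 1 to compound 4 (within the scatter). On an aromatic carbon of a five-membered aromatic ring with 3 nitrogen, 1,5-dimethyl-1H-pyrazol-3-yl can therefore stand in place of pyridazin-3-yl, a five-membered aromatic ring for a six-membered one, without a difference that this assay can separate from its usual scatter. Nothing measured here accounts for the size of this step.

The compounds shown leave open how this position responds to a quite different group, such as an amine, a carboxylic acid or a longer chain. They also leave open whether the same replacement gives a similar step on the different structures of compound 2 and compound 3.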